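A few compounds are considered here, and "the series" means these few. Any claim that something is new, unique, unknown or untested is made for them only; others in the source may bear on it.

Working notes on the series. Compound 1 `COc1ccc(Cn2c(NCCNC(=N)N)nc(=O)n(Cc3ccc(I)cc3)c2=O)cc1` and compound 2 `COc1ccc(Cn2c(NCCNC(=N)N)nc(=O)n(Cc3ccc(F)cc3)c2=O)cc1` share one core; compound 3 `COc1ccc(Cn2c(=O)nc(NCCNC(=N)N)n(Cc3ccc(I)cc3)c2=O)cc1` and compound 4 `COc1ccc(Cn2c(=O)nc(NCCNC(=N)N)n(Cc3ccc(F)cc3)c2=O)cc1` share another, and the difference between the two cores is not broken down here. In a functional assay on the whole organism (strain C57Bl/6) for inhibition, with Mus musculus as the target, with a stated time of 180 min, at 48 degrees C (a higher number here means that more compound is needed for the effect, a lower number that less compound is needed), compound 1 gives 0.051 nM, while compound 2 gives 0.00031 nM. The change from compound 1 to compound 2, (fluoro in place of iodo on an aromatic carbon), made a step of a 160-fold lower number from compound 1 to compound 2 (2.22 log units; beyond the scatter). In this assay compound 3 gives 0.039 nM, near the number for compound 1. The change from compound 3 to compound 4, (fluoro in place of iodo on an aromatic carbon), is the same change on the same kind of place. The step from compound 3 to compound 4 is expected to be a 130-fold lower number from compound 3 to compound 4 (2.11 log units; beyond the scatter), resting on the step seen from compound 1 to compound 2 in this assay. Compound 4 is accordingly estimated at 0.0003 nM in this assay, with an expected range from 0.00005 nM to 0.002 nM.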

Compound 4, half-maximal effective concentration: 0.036 nM
Beside the measured number, compound 4's estimate is 120-fold (2.08 log units) below it, outside the stated range (above it).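

On the other core, fluoro in place of iodo gives a 1.1-fold lower number from compound 3 to compound 4 (0.03 log units; within the scatter) in this assay, so the large step does not carry over, and the two cores differ in their response to this change: the same change on two cores in this assay, a 160-fold lower number (2.22 log units; beyond the scatter) from compound 1 to compound 2 and a 1.1-fold lower number (0.03 log units; within the scatter) from compound 3 to compound 4, 150-fold (2.18 log units) apart, beyond the scatter of two such steps. This shows that, for these two pairs, a step read on one core is no guide to the same change on the other. It does not show which difference between the cores matters, or why, and it sets no rule beyond these four compounds.

Going by these compounds, it remains open whether chloro, bromo or methyl in the same place would follow the pattern of the one core or the other.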